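From Amino Acid Tail to Aminoethyl Amide

The source may report more compounds than this note shows. Statements on the series, on what has been measured and on what is new or still open speak of the compounds shown alone.

Compound 1 `COc1ccc(/C=C\c2cc(OC)c(OC)c(OC)c2)cc1OCc1ccc(CNC(C)(C)C(=O)O)cc1` is tested in a functional assay on HepG2 cells (Homo sapiens) for antiproliferative activity, read by CCK-8 assay, with a stated time of 48 h (a lower number here means a stronger inhibitor, a higher number a weaker inhibitor), where compound 1 gives 6500 nM. Of the two numbers seen so far this is the highest, and the nearest is compound 3 `COc1ccc(/C=C\c2cc(OC)c(OC)c(OC)c2)cc1OCc1ccc(CN2CC[C@@H](C(=O)O)C2)cc1`, with a 2.8-fold lower number from compound 1 to compound 3 (0.45 log units; beyond the scatter) and a value for compound 3 of 2300 nM. Compound 2 `COc1ccc(/C=C\c2cc(OC)c(OC)c(OC)c2)cc1OCc1ccc(CN[C@H](C(=O)O)[C@H](C)O)cc1` gives only a limit, > 10000 nM, so its activity is not pinned to a number. This limit is the limit of > 10000 nM in this assay, at which 1 of the 3 values shown sits, and the step of an at least 1.5-fold higher number from compound 1 to compound 2 (0.18 log units; that floor lies within the scatter) can only be read as a floor.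

Compound 4 `COc1ccc(/C=C\c2cc(OC)c(OC)c(OC)c2)cc1OCc1ccc(CN2CCCCC2C(=O)NCCN)cc1` is not yet measured. It differs from compound 1 in one place: 2-((2-aminoethyl)carbamoyl)piperidin-1-yl in place of (1-carboxy-1-methylethyl)amino on a saturated chain carbon bound to an aromatic carbon. The closest measured step is the one that also ties the nitrogen into a ring, a 2.8-fold lower number from compound 1 to compound 3 (0.45 log units; beyond the scatter), which gave a modest lowering; the step that altered the acid-bearing chain, an at least 1.5-fold higher number from compound 1 to compound 2 (0.18 log units; that floor lies within the scatter), went the other way. Compound 4 keeps the ring but trades the carboxylic acid for an amide, so the expected step is small, a 1.9-fold lower number from compound 1 to compound 4 (0.27 log units; within the scatter), and the estimated value for compound 4 is 3500 nM, expected to lie between 900 nM and 14000 nM.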

Compound 4, half-maximal inhibitory concentration: 4800 nM
Compound 4: the middle estimate sits 1.4-fold (0.14 log units) below what was measured; measured number inside the range.
By their numbers in this assay, from the lowest: compound 3; then compounds 4 and 1 (each within the scatter of the next). At a limit, above all of these: compound 2.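

In this assay, the place on a saturated chain carbon bound to an aromatic carbon tolerates a tail without a carboxylic acid, since the amide-bearing piperidine cannot be told apart from the open-chain acid: a 1.4-fold lower number from compound 1 to compound 4 (0.13 log units; within the scatter). A ring at this place does not by itself match compound 3, as a 2.1-fold higher number from compound 3 to compound 4 (0.32 log units; beyond the scatter), but ring size, amide and terminal amine all change together in that step, so none of them can be singled out. Only a floor can be read for an at least 2.0-fold lower number from compound 2 to compound 4 (0.31 log units; beyond the scatter), and compound 2 stands at a limit rather than a number: the limit of > 10000 nM in this assay, at which 1 of the 4 values shown sits.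

The compounds shown leave open whether the amide or its terminal amine accounts for the gap to compound 3. A piperidine bearing a plain carboxylic acid, or a pyrrolidine bearing the same 2-aminoethyl amide, would separate ring size from tail.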